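Amide side chain change from compound 3 to compound 4

The source may report more compounds than this note shows. Statements on the series, on what has been measured and on what is new or still open speak of the compounds shown alone.

In a functional assay on PC-3 cells (Homo sapiens) for antiproliferative activity, read by MTT assay, with a stated time of 48 h (a lower number here means a stronger inhibitor, a higher number a weaker inhibitor), compound 1 (`CCn1c(C(=O)NCCCN(C)C)ccc1C(CC)(CC)c1ccc(OCCC(O)(CC)CC)c(C)c1`) gives 2150 nM and compound 2 (`CCn1c(C(=O)NCCN(C)C)ccc1C(CC)(CC)c1ccc(OCCC(O)(CC)CC)c(C)c1`) gives 870 nM while compound 3 (`CCn1c(C(=O)NCCN)ccc1C(CC)(CC)c1ccc(OCCC(O)(CC)CC)c(C)c1`) gives 2420 nM on the same scale. Two steps place that last value: a 1.1-fold higher number from compound 1 to compound 3 (0.05 log units; within the scatter) shows no separation, and a 2.8-fold higher number from compound 2 to compound 3 (0.44 log units; beyond the scatter) puts it on the weaker side. Compound 3 therefore stands level with one neighbour and weaker than the other.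

The move to compound 4 (`CCn1c(C(=O)N(CCC#N)CCC#N)ccc1C(CC)(CC)c1ccc(OCCC(O)(CC)CC)c(C)c1`) is a group of 9 heavy atoms (6 carbon, 3 nitrogen; no ring) in place of a group of 4 heavy atoms (2 carbon, 2 nitrogen; no ring), on a carbonyl carbon on a carbonyl carbon. The measured steps all vary the group on that same carbonyl carbon, and they stay small: the largest is modest (a 2.8-fold higher number from compound 2 to compound 3 (0.44 log units; beyond the scatter)). None of them covers triple bonds in the group, so they bear on this change only loosely. No shift beyond the scatter is expected in this assay, with a slight lean towards a higher number. The estimated step is a 1.2-fold higher number from compound 3 to compound 4 (0.09 log units; within the scatter) with wide uncertainty. Compound 4 is expected at 3000 nM with an estimated range from 1000 nM to 9000 nM in this read-out.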

Compound 4, half-maximal inhibitory concentration: > 50000 nM
Compound 4: no number, only a limit; the forecaster's own chance of this, stated with the estimate: 10%; middle value at least 16-fold (1.22 log units) from the limit.
By their numbers in this assay, from the lowest: compound 2; then compounds 1 and 3 (each within the scatter of the next). At a limit, above all of these: compound 4.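

In this assay compound 4 stands at a limit of the assay, not at a number: the limit of > 50000 nM in this assay, at which 1 of the 4 values shown sits. Among the compounds shown here, the group on the carbonyl carbon can therefore decide much more than the earlier compounds showed, with an at least 20-fold higher number from compound 3 to compound 4 (1.31 log units; beyond the scatter), an at least 57-fold higher number from compound 2 to compound 4 (1.75 log units; beyond the scatter) and an at least 23-fold higher number from compound 1 to compound 4 (1.36 log units; beyond the scatter), all large, whereas the widest step among the first three compounds is a 2.8-fold higher number from compound 2 to compound 3 (0.44 log units; beyond the scatter). Activity at this position does not survive every replacement, and the group entering in compound 4 brings 2 triple bonds outside aromatic rings and 0 hydrogen-bond donors in a single change.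

The compounds shown do not separate the nitrile groups from the loss of the amine. A group with a single nitrile chain, or a bis(2-aminoethyl)amino group, on that carbonyl carbon would address this.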